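Ring amide nitrogen substituent in a weak antiproliferative series

The source may hold more compounds than are shown below. What is called first, only, known or untested is meant among the compounds shown, and "the series" means these compounds.

Measured compounds:
compound 1, `O=C1COc2ccc(-c3cccc(NS(=O)(=O)c4ccc(F)cc4)c3)cc2N1C1CC1`, > 40000 nM
compound 2, `O=C1COc2ccc(-c3cnc(Cl)c(NS(=O)(=O)c4ccc(F)cc4)c3)cc2N1c1ccccc1`, 39800 nM
compound 3, `O=C1COc2ccc(-c3cnc4ccccc4c3)cc2N1c1ccc(Cl)cc1`, 36100 nM

All three compounds were tested in a functional assay on HCT-116 cells (Homo sapiens) for antiproliferative activity, read by MTT assay, with a stated time of 72 h; a lower number here means a stronger inhibitor, a higher number a weaker inhibitor. Compound 1 reaches only a limit of the assay, > 40000 nM; that limit, (the limit of > 40000 nM in this assay, at which 1 of the 3 values shown sits), is where one of the three results sits. Among the two numbers, compound 2 with 39800 nM stands highest, and the nearest number, compound 3 at 36100 nM, lies within the scatter of it, so no order between compound 2 and compound 3 can be read.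

The unmeasured compound 4, `O=C1COc2ccc(-c3cnc(Cl)c(NS(=O)(=O)c4ccc(F)cc4)c3)cc2N1`, differs from compound 2 in one place: hydrogen in place of phenyl on an amide-type nitrogen in a ring. Among the compounds with values here, no measured pair in this set shows the same change, so its size is unknown; with every compound near the limit, the step from compound 2 to compound 4 is expected to stay within the scatter or to drift toward the limit, a 1.1-fold higher number from compound 2 to compound 4 (0.05 log units; within the scatter). Compound 4 is therefore estimated at 45000 nM, in the range 15000 nM to 120000 nM, with a real chance that this assay reports only a limit.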

Compound 4, half-maximal inhibitory concentration: > 40000 nM
Compound 4: only a limit was reported; the forecaster's own chance of this, stated with the estimate: 55%; the middle value does not contradict the limit.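

In this assay, hydrogen in place of phenyl on an amide-type nitrogen in a ring gives a number no lower from compound 2 to compound 4 (the limit leaves the size open). Within the data shown here, this is the first matched pair at this position, and it shows that removing the phenyl brings no gain in this assay, although how far the number rises cannot be read. Compound 4 gives only a limit, and the series now has a second compound there: the limit of > 40000 nM in this assay, at which 2 of the 4 values shown sit.

As far as these compounds go, whether any group on this nitrogen can bring the number clearly away from the limit stays open, for example a methyl or a longer chain ending in an amine. Also open, from the compounds shown here alone, is whether this nitrogen matters at all in this assay, as the values shown all lie close to the limit.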